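Replacing the iodo group of compound 3 with methyl

The compounds below may be only part of what the source reports. "The series", "measured", "known", "first", "only" and "open" are said of these compounds alone.

In a functional assay on MDA-MB-231 cells (Homo sapiens) for antiproliferative activity, read by MTT assay, with a stated time of 72 h (on this read-out lower numbers stand for stronger inhibition and higher numbers for weaker inhibition), compound 1 `O=C(CCc1cccc2c1B(O)OC2)Nc1ccccc1` gives 230 nM and compound 2 `O=C(CCc1cccc2c1B(O)OC2)Nc1ccc(F)cc1` gives 440 nM while compound 3 `O=C(CCc1cccc2c1B(O)OC2)Nc1ccc(I)cc1` gives 33000 nM as the highest number of the three. Compound 4 `Cc1ccc(NC(=O)CCc2cccc3c2B(O)OC3)cc1` has methyl in place of iodo on an aromatic carbon and that carbon is para to a large group.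

Going by the values given here, two measured steps bear most directly on this change. Iodo in place of hydrogen gave a 140-fold higher number from compound 1 to compound 3 (2.16 log units; beyond the scatter) and iodo in place of fluoro gave a 75-fold higher number from compound 2 to compound 3 (1.88 log units; beyond the scatter) and both are large. Fluoro in place of hydrogen gave only a 1.9-fold higher number from compound 1 to compound 2 (0.28 log units; within the scatter) as a much smaller change. Among the compounds with values here, no methyl compound has been measured, so the size of the step is uncertain. A large move to a lower number is still expected, probably stopping short of the values of compound 1 and compound 2. The estimated change is a 33-fold lower number from compound 3 to compound 4 (1.52 log units; beyond the scatter) in this assay on this reasoning. The estimate for compound 4 is 1000 nM with measurements expected between 200 nM and 8000 nM in most repeats.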

Compound 4, half-maximal inhibitory concentration: 1100 nM
Compound 4: the middle estimate sits 1.1-fold (0.04 log units) below what was measured; low and high end bracket the measured number.
By their numbers in this assay, from the lowest: compounds 1 and 2 (each within the scatter of the next); then compound 4; then compound 3.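

In this assay, methyl in place of iodo gives a 30-fold lower number from compound 3 to compound 4 (1.48 log units; beyond the scatter), so the steep loss seen with iodo does not follow simply from putting one heavy atom other than hydrogen at this place, since methyl also has one. The place is still not free of cost: methyl in place of hydrogen gives a 4.8-fold higher number from compound 1 to compound 4 (0.68 log units; beyond the scatter) and methyl in place of fluoro gives a 2.5-fold higher number from compound 2 to compound 4 (0.40 log units; beyond the scatter), both modest steps, whereas the earlier step from hydrogen to fluoro stayed within the scatter. Nothing measured here accounts for the gap between iodo and methyl.

The compounds shown leave open where chloro and bromo would fall, and so whether the loss builds up across the halogens or belongs to iodo alone. They also leave open how a longer chain such as ethyl, or an amine, would behave at this same place.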